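Swapping Chloro for Methoxy on the Hydrazone Aryl Ring

The source may report more compounds than this note shows. Statements on the series, on what has been measured and on what is new or still open speak of the compounds shown alone.

Compound 1 `O=C(N/N=C/c1ccccc1)c1cccnc1Nc1cccc(C(F)(F)F)c1`: 31%
Compound 2 `O=C(N/N=C/c1cccc(F)c1)c1cccnc1Nc1cccc(C(F)(F)F)c1`: 29.8%
Compound 3 `O=C(N/N=C/c1cccc(Cl)c1)c1cccnc1Nc1cccc(C(F)(F)F)c1`: 40.4%

All three were tested in a functional assay on the whole organism (strain Wistar) for inhibition, with Rattus norvegicus as the target, read by paw edema, with a stated time of 4 h, at a dose of 10 mg/kg by the intraperitoneal route; on this read-out lower numbers stand for less inhibition and higher numbers for more inhibition at the one dose given (going by the name of the read-out). Compound 3 gives the largest number of the three, but the gap to compound 1 is within the usual scatter (a number 9.4 percentage points higher from compound 1 to compound 3 (within the scatter)), while the gap to compound 2 is beyond it (a number 10.6 percentage points higher from compound 2 to compound 3 (beyond the scatter)). The step from compound 1 to compound 2 is also within the scatter (a number 1.2 percentage points lower from compound 1 to compound 2 (within the scatter)).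

Compound 4 `COc1cccc(/C=N/NC(=O)c2cccnc2Nc2cccc(C(F)(F)F)c2)c1` differs from compound 3 in one place: methoxy in place of chloro on an aromatic carbon. Within the data shown here, no measured step involves a methoxy group, so the nearest guides are the steps that put chloro onto this position and that exchange chloro for fluoro; both are small. The hydrogen and fluoro analogues, compound 1 and compound 2, sit a little below compound 3, so a small fall back toward their values is expected, though a change within the scatter is just as plausible. The step of a number 7.4 percentage points lower from compound 3 to compound 4 (within the scatter) is therefore expected to be modest. Compound 4 is estimated to give 33%, within 22% to 44%.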

Compound 4, a percentage reported as inhibition, in the whole organism at one dose (the size of the read-out at that dose, not a potency): 14.9%
Estimate against measurement, compound 4: 18.1 percentage points above; the whole stated range lies above it.
By their numbers in this assay, from the lowest: compound 4; then compounds 2, 1 and 3 (each within the scatter of the next, the first and the last beyond it).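

Among these compounds, at this position on the ring, methoxy is the first group to move the number beyond the scatter relative to the unsubstituted compound in this assay: a number 16.1 percentage points lower from compound 1 to compound 4 (beyond the scatter). The halogen compounds show the same separation, with a number 14.9 percentage points lower from compound 2 to compound 4 (beyond the scatter) and a number 25.5 percentage points lower from compound 3 to compound 4 (beyond the scatter), so this position is not indifferent to the group placed on it, and the 3-methoxyphenyl compound stands apart from the other three. Nothing available explains what lies behind this fall.

The compounds shown leave open whether the fall is particular to methoxy or also appears with a longer ether such as ethoxy, with hydroxy, or with an amine at this place. Going by these compounds, each compound is also seen at only one dose, so how the numbers would compare at other doses remains unknown.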